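This account rests on a few compounds, and the source may have more. Where it says the series, first, only, none or still open, it means among the compounds named here.

Measured compounds:

compound 1, `COC(=O)/C=C(C)/C=C/CC(C)CCCC(C)C`: 6.2
compound 2, `COC(=O)/C=C(C)/C=C/CC(C)CCCC(C)(C)OC`: 5
compound 3, `CCOC(=O)/C=C(C)/C=C/CC(C)CCC(O)C(C)C`: 4.65

In a physicochemical assay for lipophilicity (on this read-out lower numbers stand for lower lipophilicity and higher numbers for higher lipophilicity), compound 1 stands highest of the three numbers. Its nearest neighbour is compound 2, reached by a number 1.20 log units lower from compound 1 to compound 2 (beyond the scatter). Among the measured compounds shown here, compound 3 differs from compound 1 in more than one place, so no single step is computed for that pair; its value is simply the lowest of the three.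

The unmeasured compound 4, `CC(/C=C/CC(C)CCCC(C)C)=C\C(=O)NC(C)C`, departs from compound 1 at the carbonyl carbon: isopropylamino in place of methoxy on a carbonyl carbon. For the measured compounds named here, the one computed step, from compound 1 to compound 2, concerns a methoxy entering on a saturated chain carbon and is therefore a different kind of change; nothing measured here covers an exchange of methoxycarbonyl for isopropylcarbamoyl. The step into compound 4 thus rests on the structural change alone: one hydrogen-bond acceptor leaves, one hydrogen-bond donor enters, and the heavy-atom count rises by two.

Compound 4 is expected to give 5.9 in this assay, within a range from 5.2 to 6.6. The expected step is a number 0.30 log units lower from compound 1 to compound 4 (within the scatter), a movement that may well fall within the scatter, with the direction uncertain.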

Compound 4, partition coefficient: 5.65
Beside the measured number, compound 4's estimate is 0.25 log units above it, and the stated range covers the measured number.
By their numbers in this assay, from the lowest: compound 3; then compound 2; then compound 4; then compound 1.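

In this assay, isopropylamino in place of methoxy on a carbonyl carbon gives a number 0.55 log units lower from compound 1 to compound 4 (beyond the scatter), so the series now has a measured step at this position and not only on the saturated chain. The number falls even though the entering group is the larger of the two, with 4 heavy atoms against 2, and the change also swaps a hydrogen-bond acceptor for a hydrogen-bond donor. No supporting measurement bears on what drives this step.

The compounds shown leave open whether the step follows the amide hydrogen or the isopropyl group: dimethylamino, which carries no amide hydrogen, and plain amino on the same carbonyl carbon would separate the two readings. Also open, on these data alone, are how a carboxylic acid would read at this position, and whether the step from methoxycarbonyl to isopropylcarbamoyl would hold on a chain bearing methoxy in place of hydrogen on a saturated chain carbon bound to three saturated chain carbons, where a number 1.20 log units lower from compound 1 to compound 2 (beyond the scatter) applies.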